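The source may hold more compounds than are shown below. What is called first, only, known or untested is meant among the compounds shown, and "the series" means these compounds.

For the measured compounds named here, in a functional assay on A549 cells (Homo sapiens) for cytotoxicity, read by MTT assay, with a stated time of 72 h (on this read-out higher numbers stand for an effect only at larger amounts of compound and lower numbers for an effect already at smaller amounts), compound 3 `CCOC(=O)c1c(C)coc1-c1ccc2c(CC)cccc2c1OC` gives 3.8 ug/mL, the lowest of the two actual numbers so far. Compound 1 `CCc1cccc2c(O)c(-c3occ(C)c3C(=O)O)ccc12` reads 10.6 ug/mL, a gap beyond the usual scatter. Compound 2 `CCOc1c(-c2occ(C)c2C(=O)O)ccc2c(CC)cccc12` returns only a limit, > 10 ug/mL.

Compound 4 `CCc1cccc2c(OC)c(-c3occ(C)c3COCC(F)(F)F)ccc12` keeps the core of compound 3 but carries (2,2,2-trifluoroethoxy)methyl in place of ethoxycarbonyl on an aromatic carbon of the five-membered aromatic ring with 1 oxygen ((2,2,2-trifluoroethoxy)methyl in place of ethoxycarbonyl on an aromatic carbon). This replaces a group with a double bond outside the ring by a longer chain without one.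

Going by the values given here, only one measured step changes a single place, a step that the limit leaves unreadable from compound 1 to compound 2, and it concerns a different place, so it offers no size to carry over. Among the compounds with values here, no measured step touches ethoxycarbonyl, which leaves no basis for predicting a direction or a large change. The expected step is therefore a 1.3-fold higher number from compound 3 to compound 4 (0.12 log units; within the scatter), which would stay within the scatter. For compound 4 the estimated value is 5 ug/mL, with an expected range from 1.5 ug/mL to 16 ug/mL.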

Compound 4, concentration for half-maximal effect: > 10 ug/mL
Compound 4 was reported as a limit (the forecaster's own chance of this, stated with the estimate: 20%); middle value at least 2.0-fold (0.30 log units) away from the limit.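

In this assay, putting (2,2,2-trifluoroethoxy)methyl in place of ethoxycarbonyl gives an at least 2.6-fold higher number from compound 3 to compound 4 (0.42 log units; beyond the scatter), so this place on the five-membered ring is sensitive to what it carries. For the compounds shown here, the earlier compounds offered no readable step here, and this change, unlike the only earlier single-place step, goes beyond the scatter. Compound 4 is reported only as a limit, so the step has a lower bound but no exact size: the limit of > 10 ug/mL in this assay, at which 2 of the 4 values shown sit.

The exchange removes the carbonyl and brings in the fluorines and a longer chain all at once, so the compounds shown do not tell which of these differences accounts for the step. As far as these compounds go, it also remains open whether a plain ethoxymethyl group or an amide at this place would read closer to compound 3 or to compound 4.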